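Removing the Boron-Bearing Ring from an Acetylphenyl Anilide

The source may hold more compounds than are shown below. What is called first, only, known or untested is meant among the compounds shown, and "the series" means these compounds.

Compound 1 `COc1cc(OC)cc(-c2cccc(NC(=O)CCc3cccc4c3COB4O)c2)c1` carries a fused boron-containing bicyclic group on the chain and gives 88000 nM in a functional assay on SK-OV-3 cells (Homo sapiens) for antiproliferative activity, read by MTT assay, with a stated time of 72 h; on this read-out higher numbers stand for weaker inhibition and lower numbers for stronger inhibition. Compound 2 `CC(=O)c1ccc(-c2cccc(NC(=O)CCc3cccc4c3COB4O)c2)cc1` differs from it by 4-acetylphenyl in place of 3,5-dimethoxyphenyl on an aromatic carbon and gives 57000 nM in this assay, a step of a 1.5-fold lower number from compound 1 to compound 2 (0.19 log units; within the scatter). Compound 3 `COc1cc(OC)cc(-c2cccc(NC(=O)CCc3ccccc3)c2)c1` differs from compound 1 by a group of 6 heavy atoms (6 carbon; one six-membered aromatic ring of carbon only) in place of a group of 10 heavy atoms (7 carbon, 1 boron, 2 oxygen; one five-membered non-aromatic ring with 2 hetero atoms, one six-membered aromatic ring of carbon only), on a saturated chain carbon, two bonds along the chain from a carbonyl carbon. In this assay compound 3 gives > 100000 nM, which is a limit of the assay rather than a number (the limit of > 100000 nM in this assay, at which 1 of the 3 values shown sits). The change from compound 1 to compound 3 therefore gave an at least 1.1-fold higher number from compound 1 to compound 3 (0.05 log units; that floor lies within the scatter).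

Compound 4 `CC(=O)c1ccc(-c2cccc(NC(=O)CCc3ccccc3)c2)cc1` has not yet been measured in this assay. It differs from compound 2 by a group of 6 heavy atoms (6 carbon; one six-membered aromatic ring of carbon only) in place of a group of 10 heavy atoms (7 carbon, 1 boron, 2 oxygen; one five-membered non-aromatic ring with 2 hetero atoms, one six-membered aromatic ring of carbon only), on a saturated chain carbon, two bonds along the chain from a carbonyl carbon, the same change as that from compound 1 to compound 3, at the same place; the two cores differ by 4-acetylphenyl in place of 3,5-dimethoxyphenyl on an aromatic carbon. Because compound 3 reached only the limit of > 100000 nM in this assay, at which 1 of the 3 values shown sits, after this change, compound 4 is expected to move from compound 2 by roughly a 2.6-fold higher number from compound 2 to compound 4 (0.42 log units; beyond the scatter). The value expected for compound 4 in this assay is 150000 nM, most likely again reported as a limit.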

Compound 4, half-maximal inhibitory concentration: 3200 nM
Estimate against measurement, compound 4: 47-fold (1.67 log units) above; the measured number lies below the stated range.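

On the core bearing 4-acetylphenyl, phenyl in place of the boron-containing group gives an 18-fold lower number from compound 2 to compound 4 (1.25 log units; beyond the scatter) in this assay. The same change at the same place therefore does not carry over from one core to the other in this series: the same change on two cores in this assay, an at least 1.1-fold higher number (0.05 log units; that floor lies within the scatter) from compound 1 to compound 3 and an 18-fold lower number (1.25 log units; beyond the scatter) from compound 2 to compound 4, at least 20-fold (1.30 log units) apart, beyond the scatter of two such steps
Compound 3 gives > 100000 nM, which is a limit of the assay and not a number; the two steps show that the result of the change depends on the core, but they do not show the true size of the step on the core of compound 1, nor what in 4-acetylphenyl or 3,5-dimethoxyphenyl accounts for the gap.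

The compounds shown leave open whether the lower number of compound 4 survives when an amine or a carboxylic acid takes the place of the acetyl group. They also leave open whether a longer chain carrying the phenyl group would behave in the same way on either core.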